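Shared-core series: from compound 3 to compound 4

The source may hold more compounds than are shown below. What is called first, only, known or untested is meant among the compounds shown, and "the series" means these compounds.

Compound 1 `Cc1ccc(C(=O)CSc2nnc(C)n2N2C(=O)c3ccccc3C2=O)cc1` — in a functional assay on HepG2 cells (Homo sapiens) for cytotoxicity, read by MTT assay, with a stated time of 48 h (a lower number here means a stronger inhibitor, a higher number a weaker inhibitor), compound 1 gives > 200000 nM, a limit of the assay and not a number.
Compound 2 `CCc1nnc(SCC(=O)c2ccc(C)cc2)n1N1C(=O)c2ccccc2C1=O` — in this assay compound 2 gives > 200000 nM, again a limit of the assay.
Compound 3 `COc1cc(-c2nnc(SCC(=O)c3ccc(C)cc3)n2N2C(=O)c3ccccc3C2=O)cc(OC)c1OC` — in this assay compound 3 gives 9440 nM.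

Going by the values given here, compound 3 therefore holds the only number in the set; the other two values sit at the limit of > 200000 nM in this assay, at which 2 of the 3 values shown sit. The steps of an at least 21-fold lower number from compound 1 to compound 3 (1.32 log units; beyond the scatter) and an at least 21-fold lower number from compound 2 to compound 3 (1.32 log units; beyond the scatter) are both large, whereas a step that the two limits leave unreadable from compound 1 to compound 2 cannot be read. Compound 4 `COc1cc(-c2nnc(SCC(=O)c3ccccc3C)n2N2C(=O)c3ccccc3C2=O)cc(OC)c1OC` differs from compound 3 by 2-methylphenyl in place of 4-methylphenyl on a carbonyl carbon. Among the compounds with values here, none of the measured steps touches this part of the molecule; all three concern the group on the aromatic carbon of the core, so they give no direction for this change. No step beyond the scatter is therefore expected, a 1.1-fold higher number from compound 3 to compound 4 (0.03 log units; within the scatter). For compound 4 in this assay the expected value is 10000 nM, estimated to lie between 3000 nM and 40000 nM.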

Compound 4, half-maximal inhibitory concentration: > 200000 nM
Compound 4: a limit, no number; the forecaster's own chance of this, stated with the estimate: 10%; middle value at least 20-fold (1.30 log units) from the limit.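

Exchanging 4-methylphenyl for 2-methylphenyl on a carbonyl carbon, with the same atoms joined differently, gives an at least 21-fold higher number from compound 3 to compound 4 (1.32 log units; beyond the scatter) in this assay. The earlier steps shown here concerned only the group on the aromatic carbon of the core; this one shows that 3,4,5-trimethoxyphenyl there does not by itself secure a number, since the group on the carbonyl carbon also matters. Compound 3 alone keeps a number: the limit of > 200000 nM in this assay, at which 3 of the 4 values shown sit.

Open, from the compounds shown here alone, is whether a 3-methylphenyl, a plain phenyl or a 4-chlorophenyl on the carbonyl carbon would stay close to compound 3 or fall to the limit.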